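The source may hold more compounds than are shown below. What is called first, only, known or untested is meant among the compounds shown, and "the series" means these compounds.

Going by the values given here, compound 2, `O=C(NCCO)c1cccc2c1CCN2c1cc(Cc2ccccc2C(F)(F)F)ncn1`, is one of two compounds so far tested in a functional assay on HEK293 cells for agonist activity at G-protein coupled receptor 52 (Homo sapiens), read by cAMP accumulation, with a stated time of 15 min (on this read-out lower numbers stand for an effect already at smaller amounts and higher numbers for an effect only at larger amounts of compound), and in that assay compound 2 gives 711 nM. The other measured compound, compound 1, `Cc1c(Cc2cc(F)cc(C(F)(F)F)c2)cnnc1N1CCc2c(C(=O)NCCO)cccc21`, shares the core and the amide chain but carries a different substituted pyridazine-type attachment, and in this assay compound 1 gives 754 nM. The two values lie within the usual scatter of each other, so the numbers show no separation between compound 1 and compound 2.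

Compound 3, `O=C(NCCO)c1cccc2c1CCN2c1cc(Cc2cccc(OC(F)(F)F)c2)ncn1`, has not yet been measured. It differs from compound 2 in a single place: 3-(trifluoromethoxy)phenyl in place of 2-(trifluoromethyl)phenyl on a saturated chain carbon bound to an aromatic carbon. Among the compounds with values here, no measured pair in this set shows what this kind of exchange does in this assay, so there is nothing to rest a direction on beyond the two values in hand. For that reason the step from compound 2 to compound 3 is expected to be small, as expressed by a 1.1-fold higher number from compound 2 to compound 3 (0.05 log units; within the scatter), and not beyond the scatter in either direction. Compound 3 is accordingly estimated to give about 800 nM in this assay, with a plausible range from 300 nM to 2500 nM.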

Compound 3, half-maximal effective concentration: 131 nM
Compound 3: middle estimate off by 6.1-fold (0.79 log units), on the high side; measured number below the stated range.
By their numbers in this assay, from the lowest: compound 3; then compounds 2 and 1 (each within the scatter of the next).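

In this assay, the saturated chain carbon bound to an aromatic carbon proves to be a place where the read-out responds to the group it carries: 3-(trifluoromethoxy)phenyl in place of 2-(trifluoromethyl)phenyl gives a 5.4-fold lower number from compound 2 to compound 3 (0.73 log units; beyond the scatter), a step beyond the scatter. The earlier compounds shown here could not show this, as compound 1 and compound 2 differ in more than one place and their values, which lie within the scatter of each other, isolated no single change at this position. No measurement in hand explains why this exchange lowers the number.

The exchange alters both the substituent, trifluoromethyl against trifluoromethoxy, and where it stands on the phenyl ring, so compound 2 and compound 3 cannot say how much of the step belongs to either change. From the compounds shown here alone, it also remains open how the read-out would respond if that phenyl ring carried a nitrile, an amine or a carboxylic acid instead, or if a longer chain joined the ring to the rest of the molecule.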